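Chloro in place of methyl on the aromatic ring

This account rests on a few compounds, and the source may have more. Where it says the series, first, only, none or still open, it means among the compounds named here.

Compound 1 `Cc1nc2sc(-c3ccccc3)nc2c(=O)[nH]1` gives 11% in an assay on CHO cells for displacement of a labelled ligand from adenosine receptor A1 (Homo sapiens), read by scintillation counting, with a stated time of 120 min, tested at 1 uM; on this read-out higher numbers stand for more inhibition at the one concentration tested (going by the name of the read-out) and lower numbers for less inhibition.
Compound 2 `Cc1cccc(-c2nc3c(=O)[nH]c(C)nc3s2)c1` gives 1% in this assay.

Compound 2 stands at the lowest of the two numbers in this assay; its nearest neighbour is compound 1, with a number 10 percentage points lower from compound 1 to compound 2 (within the scatter). Compound 3 `Cc1nc2sc(-c3cccc(Cl)c3)nc2c(=O)[nH]1` differs from compound 2 in one place: chloro in place of methyl on an aromatic carbon. Among the compounds with values here, no measured step exchanges methyl for chloro. Within the data shown here, the only measured step, a number 10 percentage points lower from compound 1 to compound 2 (within the scatter), concerns the same place and stays within the scatter, so no step beyond the scatter is expected in this assay. Compound 3 is therefore estimated at 8%, between -10% and 30%, a step of a number 7 percentage points higher from compound 2 to compound 3 (within the scatter) that is expected to stay within the scatter.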

Compound 3, a percentage reported as inhibition, at one concentration (the size of the read-out at that concentration, not a potency): 24%
Compound 3: the middle estimate sits 16 percentage points below what was measured, and the stated range covers the measured number.
By their numbers in this assay, from the lowest: compounds 2 and 1 (each within the scatter of the next); then compound 3.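

In this assay, within the data shown here, the earlier compounds showed no change at this position beyond the scatter, but chloro does, with a number 23 percentage points higher from compound 2 to compound 3 (beyond the scatter) when it replaces methyl and a number 13 percentage points higher from compound 1 to compound 3 (beyond the scatter) when it replaces hydrogen. The position on the aromatic ring therefore responds to the group placed there, although the step is modest and comes from a single tested concentration. No available evidence accounts for this difference between chloro and methyl. On these data alone, whether fluoro, methoxy or an amine at this position would give a larger number remains open.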